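The compounds below may be only part of what the source reports. "The series", "measured", "known", "first", "only" and "open" are said of these compounds alone.

Working notes on the series:

- compound 1 `COc1ccc2c(/C=C/C(=O)c3cc(N)c(OC)c(OC)c3)c[nH]c2c1`: 155 nM
- compound 2 `COc1cc(C(=O)/C=C/c2c[nH]c3ccccc23)cc(SC)c1OC`: 159 nM

In a functional assay on HeLa cells (Homo sapiens) for antiproliferative activity, read by MTT assay, with a stated time of 48 h (a lower number here means a stronger inhibitor, a higher number a weaker inhibitor), compound 2 gives 159 nM. Among the measured compounds shown here, with only two numbers available, its nearest and only neighbour is compound 1 at 155 nM, and the two values lie within the scatter of each other, so neither compound ranks ahead.

The next compound is compound 3 `COc1cc(C(=O)/C=C/c2c[nH]c3ccccc23)cc(N)c1OC`, which has amino in place of methylsulfanyl on an aromatic carbon, ortho to a methoxy group: amino in place of methylsulfanyl on an aromatic carbon.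

For the measured compounds named here, no measured pair isolates this exchange, so the data give no direct size for it. Going by the values given here, the one indirect hint is compound 1, which also carries an amino group and gives 155 nM. On that basis, no step beyond the scatter is expected in this assay, in either direction, although the uncertainty is wide. The expected step of a 1.1-fold lower number from compound 2 to compound 3 (0.03 log units; within the scatter) is an estimate resting on these two compounds alone. For compound 3, the expected value is 150 nM, within an estimated range of 40 nM to 550 nM.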

Compound 3, half-maximal inhibitory concentration: 529 nM
Compound 3: the middle estimate sits 3.5-fold (0.55 log units) below what was measured; measured number inside the range.
By their numbers in this assay, from the lowest: compounds 1 and 2 (each within the scatter of the next); then compound 3.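

Working notes, continued. In this assay, amino in place of methylsulfanyl on an aromatic carbon, ortho to a methoxy group, gives a 3.3-fold higher number from compound 2 to compound 3 (0.52 log units; beyond the scatter) and so provides the first direct size for this exchange: in this matched pair, the two groups are not interchangeable at this position. Compound 3 also has a second matched neighbour, reached through hydrogen in place of methoxy on an aromatic carbon, which gives a 3.4-fold higher number from compound 1 to compound 3 (0.53 log units; beyond the scatter) and shows that an amino group does not by itself keep the number seen with compound 1, since the result depends on the methoxy group elsewhere in the molecule. Nothing measured in the series bears on the reason for either step.

The compounds shown leave open whether a hydroxy group, a chlorine atom or an ethylsulfanyl group at the position of the exchange would give a number nearer that of compound 2 or that of compound 3. They also leave open whether the step for hydrogen in place of methoxy stays the same size when methylsulfanyl rather than amino is present.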